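A few compounds are considered here, and "the series" means these few. Any claim that something is new, unique, unknown or untested is made for them only; others in the source may bear on it.

Compound 1 `COc1cc(/C=C/C(=O)/C=C/c2ccco2)ccc1OCc1cn(CCCCOc2cc(=O)oc3ccccc23)nn1` gives "not active" (no number reported) in a functional assay on PC-3 cells (Homo sapiens) for inhibition, read by sulforhodamine B assay, with a stated time of 48 h, tested at 50 uM; on this read-out higher numbers stand for more inhibition of growth at the one concentration tested and lower numbers for less inhibition of growth. Compound 2 `COc1cc(/C=C/C(=O)/C=C/c2cc(OC)c(OC)c(OC)c2)ccc1OCc1cn(CCCCOc2cc(=O)oc3ccccc23)nn1` gives 5% in this assay.

Compound 2 holds the only number shown; compound 1 is reported without one. Compound 3 `COc1ccc(/C=C/C(=O)/C=C/c2ccc(OCc3cn(CCCCOc4cc(=O)oc5ccccc45)nn3)c(OC)c2)cc1` is not yet measured. It differs from compound 2 by one change: 4-methoxyphenyl in place of 3,4,5-trimethoxyphenyl on a double-bonded chain carbon bound to a double-bonded chain carbon. For the measured compounds named here, no step between two measured compounds is available, so nothing shows how such a change shifts the result. Because compound 2 gives 5%, only a small step within the scatter is expected, with no clear direction, and a number 3 percentage points higher from compound 2 to compound 3 (within the scatter) states that expectation. Compound 3 is estimated at 8%, in a range from 0% to 25%.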

Compound 3, percent growth inhibition at one concentration: "not active" (no number reported)
Nothing numeric was reported for compound 3; the estimate stays without a comparison.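

Compound 3 has no reported number, so no step from compound 2 to compound 3 can be read, and no other measurement here offers an explanation. Going by these compounds, how replacing 3,4,5-trimethoxyphenyl with 4-methoxyphenyl affects the result in this assay stays open.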